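Ester alkyl change on compound 2: cyclopropyl to cyclopentyl

This account rests on a few compounds, and the source may have more. Where it says the series, first, only, none or still open, it means among the compounds named here.

In an assay on isolated protein for inhibition of Rho-associated protein kinase 2 (Homo sapiens), read by radiometric assay (a lower number here means a stronger inhibitor, a higher number a weaker inhibitor), compound 2 `NCc1ccc(C(=O)Nc2ccncc2F)cc1-c1cccc(C(=O)OCC2CC2)c1` gives 2.7 nM, the lowest of the three numbers; compound 1 `CCCCCCOC(=O)c1cccc(-c2cc(C(=O)Nc3ccncc3)ccc2CN)c1` gives 22 nM and compound 3 `NCc1ccc(C(=O)Nc2ccncc2)cc1-c1cccc(C(=O)OCc2ccccc2)c1` gives 45 nM. Compound 4 `NCc1ccc(C(=O)Nc2ccncc2F)cc1-c1cccc(C(=O)OCC2CCCC2)c1` differs from compound 2 by cyclopentyl in place of cyclopropyl on a saturated chain carbon bound to an oxygen next to a carbonyl group. Among the measured compounds shown here, the only measured step at this place is a 2.0-fold higher number from compound 1 to compound 3 (0.31 log units; beyond the scatter), a modest shift from one group on a saturated chain carbon bound to an oxygen next to a carbonyl group to another. The present change is of the same kind, so a step of at most similar size, possibly none beyond the scatter, is expected in this assay, with weakening slightly more likely. Compound 4 is estimated at 4 nM (range 1.5 nM to 10 nM), an expected 1.5-fold higher number from compound 2 to compound 4 (0.17 log units; within the scatter).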

Compound 4, half-maximal inhibitory concentration: 13 nM
Compound 4: middle estimate off by 3.3-fold (0.51 log units), on the low side, and the stated range ends below it.
By their numbers in this assay, from the lowest: compound 2; then compounds 4 and 1 (each within the scatter of the next); then compound 3.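

In this assay, the place on the saturated chain carbon bound to an oxygen next to a carbonyl group responds to ring size: cyclopentyl in place of cyclopropyl gives a 4.8-fold higher number from compound 2 to compound 4 (0.68 log units; beyond the scatter). Among the compounds shown here, the step is numerically larger than a 2.0-fold higher number from compound 1 to compound 3 (0.31 log units; beyond the scatter), though that pair has a different core, so this single pair is the only direct reading for the core of compound 2. Nothing available explains the loss.

Open, from the compounds shown here alone, is whether cyclobutyl would fall between cyclopropyl and cyclopentyl. Also open, going by these compounds, is whether an amine or carboxylic acid on the chain would be tolerated.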